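The source may hold more compounds than are shown below. What is called first, only, known or untested is meant among the compounds shown, and "the series" means these compounds.

Three esters of a shared core were tested in a functional assay on HeLa cells (Homo sapiens) for cytotoxicity, read by MTT assay, with a stated time of 48 h; on this read-out lower numbers stand for stronger inhibition and higher numbers for weaker inhibition. Compound 1 `COc1ccc(-n2cc(COC(=O)c3cc4ccccc4[nH]3)nn2)cc1` gives 16100 nM in this assay. Compound 2 `O=C(OCc1cn(-c2cccc(C(F)(F)F)c2)nn1)c1cc2ccccc2[nH]1` gives 11700 nM, and compound 3 `Cc1cc(C)cc(-n2cc(COC(=O)c3cc4ccccc4n3Cc3cn(-c4cc(C)cc(C)c4)nn3)nn2)c1`, which carries a second triazolylmethyl group on the indole nitrogen of the core, gives 28800 nM. The number for compound 1 sits alongside those of its two companions: its gap to compound 2 and its gap to compound 3 both fall within the usual scatter of repeated measurements, so none of the three can be set apart from the others on these figures.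

Compound 4 `O=C(OCc1cn(-c2ccccc2Br)nn1)c1cc2ccccc2[nH]1` has not yet been measured. It differs from compound 1 at a single place: 2-bromophenyl in place of 4-methoxyphenyl on an aromatic nitrogen. Within the data shown here, no pair of measured compounds shows this particular exchange, so the only guidance comes from compound 2, whose trifluoromethylphenyl group in the same position gives 11700 nM, a number within the scatter of that for compound 1.

On that basis the step from compound 1 to compound 4 is expected to be small, a 1.3-fold lower number from compound 1 to compound 4 (0.13 log units; within the scatter), not clearly beyond the scatter in either direction. Compound 4 is therefore estimated at 12000 nM in this assay, with a plausible range from 5000 nM to 30000 nM.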

Compound 4, half-maximal inhibitory concentration: 17300 nM
Beside the measured number, compound 4's estimate is 1.4-fold (0.16 log units) below it; the measured number falls inside the stated range.
By their numbers in this assay, from the lowest: compounds 2, 1, 4 and 3 (each within the scatter of the next, the first and the last beyond it).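

In this assay, among these compounds, the exchange gives the first direct step at this position, a 1.1-fold higher number from compound 1 to compound 4 (0.03 log units; within the scatter), so swapping 4-methoxyphenyl for 2-bromophenyl on the aromatic nitrogen does not move the number beyond the scatter. The exchange changes the substituent on the phenyl ring and its placement, and the group that leaves counts 1 hydrogen-bond acceptor where the group that enters counts 0, yet this pair of compounds can't be told apart on cytotoxicity. No separate measurement accompanies the step, so the data offer no explanation for this result.

The compounds shown leave open whether this position tolerates only a change among substituted phenyl groups, or whether replacing the phenyl ring with a group of another kind, such as an amine, a carboxylic acid or a longer alkyl chain, would carry the number clearly beyond the scatter. They also leave open whether an amide in place of the ester linking the shared core to the rest of the molecule would change the number in this assay.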